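The compounds below may be only part of what the source reports. "The series", "measured", "known", "first", "only" and "open" are said of these compounds alone.

Compound 1 `Nc1ccccc1NC(=O)c1ccc(COc2ccc([N+](=O)[O-])cc2)cc1`: > 32000 nM
Compound 2 `CCc1ccc(OCc2ccc(C(=O)Nc3ccccc3N)cc2)cc1`: 4830 nM

Among the compounds with values here, in a functional assay on HCT-116 cells (Homo sapiens) for antiproliferative activity, read by CCK-8 assay, with a stated time of 72 h (on this read-out higher numbers stand for weaker inhibition and lower numbers for stronger inhibition), compound 2 gives 4830 nM, the only exact number so far. Compound 1 gives > 32000 nM, which is a limit of this assay and not a number.

Compound 3 `Cc1ccc(OCc2ccc(C(=O)Nc3ccccc3N)cc2)cc1` differs from compound 2 in one place: hydrogen in place of methyl on a saturated chain carbon bound to an aromatic carbon. Hydrogen stands in place of methyl on a saturated chain carbon bound to an aromatic carbon, turning ethyl into methyl.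

Within the data shown here, only one measured step bears on this change: an at least 6.6-fold lower number from compound 1 to compound 2 (0.82 log units; beyond the scatter), with ethyl in place of nitro on an aromatic carbon. That step exchanged nitro for ethyl, whereas ethyl and methyl are far closer in structure, so a much smaller step is expected, probably none beyond the scatter. The expected change is a 1.1-fold higher number from compound 2 to compound 3 (0.06 log units; within the scatter). For compound 3 the estimated value is 5500 nM, with an expected range of 2400 nM to 12000 nM.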

Compound 3, half-maximal inhibitory concentration: 4860 nM
Estimate against measurement, compound 3: 1.1-fold (0.05 log units) above, and the stated range covers the measured number.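

In this assay, going from 4-ethylphenyl to 4-methylphenyl gives a 1.0-fold higher number from compound 2 to compound 3 (0.00 log units; within the scatter), so ethyl and methyl cannot be told apart at this position. The earlier compounds shown here showed only that ethyl differs from nitro, and now methyl in place of nitro gives an at least 6.5-fold lower number from compound 1 to compound 3 (0.81 log units; beyond the scatter), which means the gap from compound 1 is not tied to ethyl alone. The true size of that gap stays unknown, since compound 1 gives a limit and not a number: the limit of > 32000 nM in this assay, at which 1 of the 3 values shown sits.

On these data alone, two alkyl groups on one ring position give little to go on, so it remains open how far the chain can grow, for instance to propyl or tert-butyl. As far as these compounds go, it is also open how an amine or a carboxylic acid at this place would read out in this assay.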